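Methoxy for bromo on the aniline ring: an expected step

The source may report more compounds than this note shows. Statements on the series, on what has been measured and on what is new or still open speak of the compounds shown alone.

Measured compounds:
compound 1 `Cc1ccc(Nc2nc(-n3ccnc3C)cs2)cc1` with > 100000 nM
compound 2 `Cc1nccn1-c1csc(Nc2cccc(Br)c2)n1` with > 100000 nM
compound 3 `Cc1nc2ccccc2n1-c1csc(Nc2ccc(Br)cc2)n1` with 60000 nM

In a functional assay on RKO cells (Homo sapiens) for cytotoxicity, read by resazurin assay, with a stated time of 72 h (a higher number here means a weaker inhibitor, a lower number a stronger inhibitor), compound 1 gives > 100000 nM, and this is a limit of the assay rather than a number. Compound 2 likewise gives > 100000 nM, again a limit and not a number. Among the compounds with values here, compound 3 is the one compound with a numeric value, 60000 nM. Within the data shown here, compound 2 therefore stands only at a limit, and of the three values shown, one more is a limit as well; no step between two measured compounds can be counted here.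

The unmeasured compound 4 `COc1cccc(Nc2nc(-n3ccnc3C)cs2)c1` differs from compound 2 in one place: methoxy in place of bromo on an aromatic carbon.

Among the measured compounds shown here, with no counted step between measured compounds, the expectation for compound 4 rests on where compound 2 sits, because the limit of > 100000 nM in this assay, at which 2 of the 3 values shown sit, is where two of the three values gather. In this assay the expected step is a number no higher from compound 2 to compound 4 (the limit leaves the size open), that is none beyond the usual scatter. Compound 4 is accordingly estimated at 100000 nM, with a range from 30000 nM to 300000 nM, and the assay may well report only a limit again.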

Compound 4, half-maximal inhibitory concentration: > 100000 nM
Compound 4 gave a limit, no number; the forecaster's own chance of this, stated with the estimate: 70%; the middle value sits exactly at the limit.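

In this assay compound 2 and compound 4 both stand at a limit and not at a number, so no step can be read between them: the limit of > 100000 nM in this assay, at which 3 of the 4 values shown sit. The compounds shown leave open whether methoxy in place of bromo on an aromatic carbon changes the cytotoxicity at all, and by how much.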